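Aryl variation on the saturated ring carbon: cytotoxicity notes

The source may report more compounds than this note shows. Statements on the series, on what has been measured and on what is new or still open speak of the compounds shown alone.

Values in a functional assay on Ehrlich cells (Mus musculus) for cytotoxicity, tested at 25 ug/mL; a higher number here means a stronger effect of the compound at the concentration tested, a lower number a weaker effect:
compound 1 `COc1cc(N2C(N)=C(C#N)C(c3ccc([N+](=O)[O-])cc3)C3=C2CC(C)(C)CC3=O)cc(OC)c1OC`: 50%
compound 2 `COc1cc(N2C(N)=C(C#N)C(c3c(OC)ccc4ccccc34)C3=C2CC(C)(C)CC3=O)cc(OC)c1OC`: 5%
compound 3 `COc1cc(N2C(N)=C(C#N)C(c3ccc(Cl)cc3Cl)C3=C2CC(C)(C)CC3=O)cc(OC)c1OC`: 55%

Compound 3 gives the highest of the three numbers; compound 1 sits within the scatter of it, while compound 2 lies far below, as a number 50 percentage points higher from compound 2 to compound 3 (beyond the scatter) shows. Compound 4 `COc1cc(N2C(N)=C(C#N)C(c3ccc(O)cc3)C3=C2CC(C)(C)CC3=O)cc(OC)c1OC` is not yet measured. Its change from compound 3: 4-hydroxyphenyl in place of 2,4-dichlorophenyl on a saturated ring carbon. For the measured compounds named here, two steps bear on it. a number 5 percentage points higher from compound 1 to compound 3 (within the scatter) is within the scatter, so exchanging one substituted six-membered aromatic ring for another has so far changed little. a number 45 percentage points lower from compound 1 to compound 2 (beyond the scatter) is large, but it involved the two-ring group, unlike the entering group here. A small step, not beyond the scatter, is therefore expected, a number 10 percentage points lower from compound 3 to compound 4 (within the scatter). Compound 4 is estimated at 45%, range 20% to 65%.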

Compound 4, a percentage reported as activity, at one concentration (the size of the read-out at that concentration, not a potency): 20%
Estimate against measurement, compound 4: 25 percentage points above, within the range that was stated.
By their numbers in this assay, from the lowest: compound 2; then compound 4; then compounds 1 and 3 (each within the scatter of the next).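

In this assay the aryl group on this saturated ring carbon is not freely exchangeable among single six-membered aromatic rings: hydroxy in place of nitro gives a number 30 percentage points lower from compound 1 to compound 4 (beyond the scatter) and 4-hydroxyphenyl in place of 2,4-dichlorophenyl gives a number 35 percentage points lower from compound 3 to compound 4 (beyond the scatter) in the same direction. The 2-methoxynaphthalen-1-yl group still sits lowest, with a number 15 percentage points higher from compound 2 to compound 4 (beyond the scatter) for that exchange. Nothing available accounts for these steps. As far as these compounds go, whether they belong to the hydroxy group alone stays open; a methoxy or amino group on the same aromatic carbon would bear on that.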